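The source may hold more compounds than are shown below. What is called first, only, known or untested is meant among the compounds shown, and "the series" means these compounds.

In a functional assay on HL-60 cells (Homo sapiens) for cytotoxicity, read by MTT assay, with a stated time of 96 h (on this read-out lower numbers stand for stronger inhibition and higher numbers for weaker inhibition), compound 2 `CC[C@H](N)C(=O)N[C@@H]1C(=O)N2[C@@H](CC[C@@H]1CCO)CC[C@H]2C(=O)NC(c1ccccc1)c1ccccc1` gives > 100000 nM, which is a limit and not a number. This reading is the limit of > 100000 nM in this assay, at which 1 of the 3 values shown sits. Compound 4 `CC[C@H](N)C(=O)N[C@@H]1C(=O)N2[C@@H](CC[C@@H]1CCNCc1ccccc1)CC[C@H]2C(=O)NC(c1ccccc1)c1ccccc1` differs from compound 2 by a single change, benzylamino in place of hydroxy on a saturated chain carbon, two bonds along the chain from a saturated ring carbon. Two relatives, compound 1 `CC[C@H](NC)C(=O)N[C@@H]1C(=O)N2[C@@H](CC[C@@H]1CCN)CC[C@H]2C(=O)NC(c1ccccc1)c1ccccc1` and compound 3 `CC[C@H](NC)C(=O)N[C@@H]1C(=O)N2[C@@H](CC[C@@H]1CCNC(=O)NCc1ccccc1)CC[C@H]2C(=O)NC(c1ccccc1)c1ccccc1`, carry nitrogen on that chain and also a methyl on the other amine, which compound 2 and compound 4 both lack. Compound 1 gives 31000 nM and compound 3 gives 52200 nM. For the measured compounds named here, the one measured step that bears on the change is a 1.7-fold higher number from compound 1 to compound 3 (0.23 log units; within the scatter), so a larger group on that chain nitrogen left the number within the scatter. A move down from the limit into the range of these two compounds is therefore expected, of modest size. The expected step is an at least 2.2-fold lower number from compound 2 to compound 4 (0.34 log units; beyond the scatter). For compound 4 the estimated value is 45000 nM, with an expected range of 15000 nM to 100000 nM.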

Compound 4, half-maximal inhibitory concentration: 15400 nM
Compound 4: middle estimate off by 2.9-fold (0.47 log units), on the high side, and the stated range covers the measured number.
By their numbers in this assay, from the lowest: compounds 4, 1 and 3 (each within the scatter of the next, the first and the last beyond it). At a limit, above all of these: compound 2.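

In this assay, for the compounds shown here, this position proved able to respond: the change gives an at least 6.4-fold lower number from compound 2 to compound 4 (0.81 log units; beyond the scatter), whereas the only earlier step on this chain, a 1.7-fold higher number from compound 1 to compound 3 (0.23 log units; within the scatter), did not move the number beyond the scatter. Benzylamino in place of hydroxy is thus the first change shown at this place with a step beyond the scatter. The full size of that step stays unknown, since compound 2 stands at a limit and not a number: the limit of > 100000 nM in this assay, at which 1 of the 4 values shown sits.

On these data alone, it remains open whether the nitrogen alone or the whole benzyl group carries the step; a plain amino group or a phenethylamino group in place of hydroxy on this chain would separate the two. Also open, as far as these compounds go, is what the methyl on the other amine, present in compound 1 and compound 3, does on its own.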